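The source may report more compounds than this note shows. Statements on the series, on what has been measured and on what is new or still open speak of the compounds shown alone.

Working notes on the series. Compound 1 `CNC(=O)c1cc2ncn(-c3ccc(C#N)cc3)c2cc1Oc1c(C)cc(/C=C/C#N)cc1C` and compound 2 `CNC(=O)c1cc2ncn(-c3ccc(C#N)cc3)c2cc1Oc1c(C)cc(CCC#N)cc1C` share one core; compound 3 `COC(=O)c1cc(N)c(Nc2ccc(C#N)cc2)cc1Oc1c(C)cc(CCC#N)cc1C` and compound 4 `COC(=O)c1cc(N)c(Nc2ccc(C#N)cc2)cc1Oc1c(C)cc(/C=C/C#N)cc1C` share another, and the difference between the two cores is not broken down here.

In an ADME assay on TZM cells (Homo sapiens) for cytotoxicity, read by XTT assay, with a stated time of 4 days (a higher number here means that more compound is tolerated, a lower number that less compound is tolerated), compound 1 gives > 890000 nM, which is a limit of the assay and not a number. In this assay compound 2 gives > 890000 nM, again a limit. The step that the two limits leave unreadable from compound 2 to compound 1 is unreadable because the limit of > 890000 nM in this assay, at which 2 of the 3 values shown sit, sits at both of its ends. The change behind that step is 2-cyanoethenyl in place of 2-cyanoethyl on an aromatic carbon.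

In this assay compound 3 gives > 22700 nM, which is also only a limit. For compound 3 the whole of what is known is the limit of > 22700 nM in this assay, at which 1 of the 3 values shown sits.

Going by the values given here, compound 4 differs from compound 3 by 2-cyanoethenyl in place of 2-cyanoethyl on an aromatic carbon, the same change as the one between compound 2 and compound 1; the surroundings of the place are described in the same words in both cases. The earlier instance of this change gave no readable step, as a step that the two limits leave unreadable from compound 2 to compound 1 shows, so no shift beyond the scatter is expected from the same change here. Compound 4 is therefore expected to remain at or beyond its limit in this assay. Compound 4 is estimated at about 50000 nM, within an expected band from 15000 nM to 500000 nM. The step that the limit leaves unreadable from compound 3 to compound 4 that this estimate implies is expected to be close to nil, and a readable number, rather than a limit, is not expected.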

Compound 4, half-maximal cytotoxic concentration in the TZM assay: > 22800 nM
Compound 4: no number, only a limit (the forecaster's own chance of this, stated with the estimate: 85%); the middle value is on the limit's open side.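

In the TZM assay compound 3 gives > 22700 nM, which is a limit of the assay and not a number. In the TZM assay compound 4 gives > 22800 nM, which is also a limit of the assay and not a number. In the TZM assay no new step can be read from compound 3 to compound 4: each of the two compounds is known only by a limit of the assay, not by a number. The compounds shown leave open how far 2-cyanoethenyl in place of 2-cyanoethyl shifts the half-maximal cytotoxic concentration on either core in the TZM assay, as all four values there are limits. In a physicochemical assay for solubility, with a stated time of 4 h, at pH 7.4 (a higher number here means a more soluble compound, a lower number a less soluble compound), compound 3 gives 1.21 ug/mL and compound 4 gives 1.3 ug/mL. In the physicochemical assay the step is a 1.1-fold higher number from compound 3 to compound 4 (0.03 log units; within the scatter).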